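From Methoxy to Fluoro: What Compound 3 Might Show

The source may hold more compounds than are shown below. What is called first, only, known or untested is meant among the compounds shown, and "the series" means these compounds.

In an ADME assay on MT4 cells (Homo sapiens) for cytotoxicity, read by MTT assay, with a stated time of 4 days (on this read-out higher numbers stand for lower toxicity in this test and lower numbers for higher toxicity in this test), compound 1 (`COc1c(-c2ccccc2F)oc2ccc(NC(C)=O)cc2c1=O`) gives 180000 nM and compound 2 (`COc1ccccc1-c1oc2ccc(N)cc2c(=O)c1OC`) gives 229000 nM. These two numbers lie within the usual scatter of each other, so compound 2 stands level with compound 1. Compound 3 (`COc1c(-c2ccccc2F)oc2ccc(N)cc2c1=O`) has fluoro in place of methoxy on an aromatic carbon of compound 2: fluoro in place of methoxy on an aromatic carbon. Going by the values given here, no measured pair shows this change on its own, so no shift beyond the scatter is expected in this assay. The expected change is a 1.1-fold lower number from compound 2 to compound 3 (0.06 log units; within the scatter). For compound 3 the estimated value is 200000 nM, within a range of 100000 nM to 350000 nM.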

Compound 3, half-maximal cytotoxic concentration: 234000 nM
The estimate for compound 3 lay 1.2-fold (0.07 log units) below the measured number, within the range that was stated.
By their numbers in this assay, from the lowest: compounds 1, 2 and 3 (each within the scatter of the next).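

In this assay, fluoro in place of methoxy on this aromatic carbon, ortho to a large group, gives a 1.0-fold higher number from compound 2 to compound 3 (0.01 log units; within the scatter), so these two groups cannot be told apart in this test. Hydrogen in place of acetyl on the nitrogen gives a 1.3-fold higher number from compound 1 to compound 3 (0.11 log units; within the scatter), so that second place shows no separation either. Nothing available here explains these results.

On these data alone, it remains open whether a carboxylic acid or a nitrile on that aromatic carbon would move the number beyond the scatter. The same question stands for a chain longer than acetyl on the nitrogen.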